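A few compounds are considered here, and "the series" means these few. Any claim that something is new, unique, unknown or untested is made for them only; others in the source may bear on it.

In a functional assay on P388 cells (Mus musculus) for inhibition (a lower number here means a stronger inhibitor, a higher number a weaker inhibitor), compound 3 `COc1ccc(/C=C/c2ccc3ccccc3c2)cc1N` gives no number, only a limit of > 5000 nM. Compound 4 `COc1ccc(/C=C\c2ccc3ccccc3c2)cc1N` differs from it in one way: the two compounds have the same atoms and bonds and differ only in configuration as drawn: 1 of 1 stereo elements differ; a double bond is drawn E in compound 3 and Z in compound 4. Within the data shown here, no measured pair isolates this change, so the closest guide is the two compounds that share the double bond drawn Z. Compound 1 `COCCOc1cc(/C=C\c2ccc3ccccc3c2)ccc1OC` gives 2990 nM. Compound 2 `COc1ccc(/C=C\c2ccc3ccccc3c2)cc1[N+](=O)[O-]` gives only a limit, > 20000 nM. Among the measured compounds shown here, the one measured step, an at least 6.6-fold higher number from compound 1 to compound 2 (0.82 log units; beyond the scatter), shows that a Z double bond alone does not settle the result. Even so, a move toward a lower number is expected, with compound 1 at 2990 nM as the reference. The expected step is an at least 5.0-fold lower number from compound 3 to compound 4 (0.69 log units; beyond the scatter). The estimate for compound 4 is 1000 nM, within a range of 100 nM to 6000 nM.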

Compound 4, half-maximal inhibitory concentration: 1820 nM
For compound 4 the middle estimate is 1.8-fold (0.26 log units) below the measured one, and the stated range covers the measured number.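

In this assay, with the amino group in place, the configuration of the double bond alone shifts the result, an at least 2.7-fold lower number from compound 3 to compound 4 (0.43 log units; beyond the scatter), and nothing else separates the pair: the fact that compounds 3 and 4 differ only in the configuration as drawn Among the compounds with the double bond drawn Z, the group at this position also matters, an at least 10-fold lower number from compound 2 to compound 4 (1.04 log units; beyond the scatter), whereas the other change gives a 1.6-fold lower number from compound 1 to compound 4 (0.22 log units; within the scatter), so amino and 2-methoxyethoxy are not told apart here. Compound 2 and compound 3 carry only limits, so those two steps are minimum sizes.

As far as these compounds go, whether the E form would also give a weaker result with 2-methoxyethoxy in place of amino stays open. So does how a hydroxyl or an acetamide group at this position would compare with amino.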